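The compounds below may be only part of what the source reports. "The series", "measured", "known", "first", "only" and "open" are said of these compounds alone.

Of the compounds shown here, three sharing one core have been measured in a functional assay on HepG2 cells (Homo sapiens) for inhibition, read by MTT assay, with a stated time of 72 h; on this read-out higher numbers stand for weaker inhibition and lower numbers for stronger inhibition. There, compound 1 (`Cc1ccc(NC(=O)C2CCN(C/C=C/c3ccccc3)CC2)cc1`) gives 33900 nM, compound 2 (`CCc1ccc(NC(=O)C2CCN(C/C=C/c3ccccc3)CC2)cc1`) gives 23300 nM, and compound 3 (`COc1ccc(NC(=O)C2CCN(C/C=C/c3ccccc3)CC2)cc1`) gives 88800 nM. Compound 3 thus carries the highest number of the three and is the weakest inhibitor in this small set.

In compound 4 (`COc1cccc(NC(=O)C2CCN(C/C=C/c3ccccc3)CC2)c1`), 3-methoxyphenyl stands in place of 4-methoxyphenyl on an amide-type nitrogen: 3-methoxyphenyl in place of 4-methoxyphenyl on an amide-type nitrogen. The two have the same atoms, joined differently. Among the compounds with values here, no measured step shows such a change, so the evidence is only indirect.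

The nearest guides are the two steps that introduce methoxy on an aromatic carbon, a 2.6-fold higher number from compound 1 to compound 3 (0.42 log units; beyond the scatter) and a 3.8-fold higher number from compound 2 to compound 3 (0.58 log units; beyond the scatter). Both are modest. The remaining step, a 1.5-fold lower number from compound 1 to compound 2 (0.16 log units; within the scatter), shows that a small change to the group can also leave the number within the scatter. Going by the modest size of the steps to compound 3, a large change is not expected from moving the same group.

The expected outcome in this assay is no step beyond the scatter, with a slight lean towards a lower number, estimated as a 1.5-fold lower number from compound 3 to compound 4 (0.17 log units; within the scatter). The estimate for compound 4 is 60000 nM, with an expected range from 25000 nM to 130000 nM.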

Compound 4, half-maximal inhibitory concentration: 78600 nM
Compound 4: the middle estimate sits 1.3-fold (0.12 log units) below what was measured; the measured number falls inside the stated range.
By their numbers in this assay, from the lowest: compounds 2 and 1 (each within the scatter of the next); then compounds 4 and 3 (each within the scatter of the next).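

In this assay, 3-methoxyphenyl in place of 4-methoxyphenyl on an amide-type nitrogen gives a 1.1-fold lower number from compound 3 to compound 4 (0.05 log units; within the scatter), so the two methoxy-bearing groups cannot be told apart at this place on this read-out. The separation from the alkyl-bearing groups remains with the new group: 3-methoxyphenyl in place of 4-ethylphenyl gives a 3.4-fold higher number from compound 2 to compound 4 (0.53 log units; beyond the scatter), and 3-methoxyphenyl in place of 4-methylphenyl gives a 2.3-fold higher number from compound 1 to compound 4 (0.37 log units; beyond the scatter), so compound 4 joins compound 3 on the higher-number side of compound 1 and compound 2. Nothing shown here offers an explanation for any of these steps.

The compounds shown leave open whether the same rearrangement of a methyl or ethyl group on the aromatic ring would also stay within the scatter, since methoxy is the only group seen in two arrangements. They also leave open how an amine, a carboxylic acid or a longer alkoxy chain would read on that ring in this assay, and whether any such group would give a number well away from those of the four compounds.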